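This account rests on a few compounds, and the source may have more. Where it says the series, first, only, none or still open, it means among the compounds named here.

Going by the values given here, in a functional assay on brain (Rattus norvegicus, strain Wistar) for inhibition (on this read-out higher numbers stand for weaker inhibition and lower numbers for stronger inhibition), compound 1 (`Cc1[nH]c(=O)n(C2CCCCC2)c1-c1ccccc1`) gives 47600 nM and stands highest of the two numbers measured so far. Compound 2 (`CCCc1ccc(-c2c(C)[nH]c(=O)n2C2CCCCC2)cc1`) gives 13900 nM on the same read-out. Compound 3 (`Cc1[nH]c(=O)n(C2CCCCC2)c1-c1ccccc1OC(C)C`) keeps the core of compound 1 and differs from it by isopropoxy in place of hydrogen on an aromatic carbon (isopropoxy in place of hydrogen on an aromatic carbon, ortho to a large group). Among the compounds with values here, only one measured step bears on this change. Propyl in place of hydrogen on an aromatic carbon gave a 3.4-fold lower number from compound 1 to compound 2 (0.53 log units; beyond the scatter) and that step is modest but beyond the scatter. Within the data shown here, no measured compound carries isopropoxy, so this precedent guides only loosely. A similarly modest move towards a lower number in this assay is expected. The estimated change is a 2.2-fold lower number from compound 1 to compound 3 (0.34 log units; beyond the scatter) and it remains uncertain in size. Compound 3 is expected at 22000 nM with an estimated range from 7000 nM to 70000 nM as the likely span.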

Compound 3, half-maximal inhibitory concentration: 21500 nM
Compound 3: the middle estimate sits 1.0-fold (0.01 log units) above what was measured; the range from low to high includes it.
By their numbers in this assay, from the lowest: compounds 2 and 3 (each within the scatter of the next); then compound 1.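

In this assay the isopropoxy group, placed on an aromatic carbon ortho to a large group, gives a 2.2-fold lower number from compound 1 to compound 3 (0.35 log units; beyond the scatter) and so brings a modest gain in inhibition over the unsubstituted aromatic ring. This is the first substituent shown at this place, and it shows that a branched group of 4 heavy atoms, joined through oxygen and carrying one hydrogen-bond acceptor, is accepted there without any loss of inhibition. No measurement is available that explains the step.

The compounds shown leave open whether the gain belongs to the oxygen, to the branching or to the size of the group, which methoxy or a plain isopropyl group at this place could separate. They also leave open how an amine or a carboxylic acid would fare there.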